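The compounds below may be only part of what the source reports. "The series", "measured", "known", "first", "only" and "open" are said of these compounds alone.

Measured in a functional assay on Doay cells (Homo sapiens) for cytotoxicity; on this read-out higher numbers stand for weaker inhibition and lower numbers for stronger inhibition:
- Compound 1 `C=C1C(=O)O[C@]2(C)CC[C@@H]1C[C@H](O)[C@@]1(C)CC[C@H](O1)[C@](C)(O)CC[C@H]2O`: > 20 ug/mL
- Compound 2 `C=C1C(=O)O[C@]2(C)CC[C@@H]1C[C@H](O)[C@@]1(C)CC[C@H](O1)[C@](C)(O)CCC2=O`: > 20 ug/mL

Compound 2 gives > 20 ug/mL, which is a limit of the assay and not a number. Compound 1 also gives only a limit, > 20 ug/mL. The two compounds therefore stand together, as the limit of > 20 ug/mL in this assay, at which 2 of the 2 values shown sit, and neither has a numerical value.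

Compound 3 `C=C1C(=O)O[C@]2(C)CC[C@@H]1C[C@H](OC(C)=O)[C@@]1(C)CC[C@H](O1)[C@](C)(O)CCC2=O` keeps the core of compound 2 but carries acetyl in place of hydrogen on an oxygen on a saturated carbon, hydroxy to acetoxy: acetyl in place of hydrogen on an oxygen on a saturated carbon. Going by the values given here, no measured pair shows what this change does. The estimated shift in this assay is small and toward stronger inhibition, an at least 1.1-fold lower number from compound 2 to compound 3 (0.04 log units; that floor lies within the scatter). A reading that is again only a limit is also expected to be quite possible. For compound 3 the expected value is 18 ug/mL, with an estimated range of 6 ug/mL to 40 ug/mL.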

Compound 3, half-maximal inhibitory concentration: > 20 ug/mL
Compound 3: no number, only a limit; the forecaster's own chance of this, stated with the estimate: 55%; middle value at least 1.1-fold (0.04 log units) away from the limit.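

Compound 3 gives > 20 ug/mL, again a limit and not a number. Going by these compounds alone, compound 2 also stands at a limit, so no step between compound 2 and compound 3 can be read. The compounds shown leave open whether changing hydroxy to acetoxy alters inhibition in this assay at all.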